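From propoxy to isobutoxy: one added methyl

A few compounds are considered here, and "the series" means these few. Any claim that something is new, unique, unknown or untested is made for them only; others in the source may bear on it.

Measured in a functional assay on RAW264.7 cells (Mus musculus) for inhibition; a higher number here means a weaker inhibitor, a lower number a stronger inhibitor:
Compound 1 `CCOC(=O)C1=CCCCC1S(=O)(=O)Nc1cccc(F)c1`: 150 nM
Compound 2 `CCOC(=O)C1=CCCCC1S(=O)(=O)Nc1c(F)cccc1F`: 160 nM
Compound 3 `CCCOC(=O)C1=CCCCC1S(=O)(=O)Nc1ccc(F)cc1F`: 29 nM

Compound 3 stands lowest of the three at 29 nM, and so is the strongest inhibitor measured so far. Compound 1 at 150 nM and compound 2 at 160 nM both lie beyond the scatter from it and within the scatter of each other. Compound 3 differs from both of them in more than one place, so these values do not isolate the effect of any single change.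

Compound 4 `CC(C)COC(=O)C1=CCCCC1S(=O)(=O)Nc1ccc(F)cc1F` is the next to be considered. It departs from compound 3 by methyl in place of hydrogen on a saturated chain carbon bound to two saturated chain carbons, turning propoxy to isobutoxy. Within the data shown here, no measured pair shows a change of this kind, so the expectation is only a small weakening in this assay, or none beyond the scatter. The expected step is a 1.4-fold higher number from compound 3 to compound 4 (0.14 log units; within the scatter). Compound 4 is estimated at 40 nM, with an expected range of 15 nM to 110 nM.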

Compound 4, half-maximal inhibitory concentration: 49 nM
Compound 4: the middle estimate sits 1.2-fold (0.09 log units) below what was measured, within the range that was stated.
By their numbers in this assay, from the lowest: compounds 3 and 4 (each within the scatter of the next); then compounds 1 and 2 (each within the scatter of the next).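

In this assay, among these compounds, the change from propoxy to isobutoxy gives a 1.7-fold higher number from compound 3 to compound 4 (0.23 log units; within the scatter) and provides the first comparison that differs in one place. At this saturated chain carbon, bound to two saturated chain carbons, methyl in place of hydrogen therefore produces no change beyond the scatter, and compound 4 stays apart from compounds 1 and 2 in the same way as compound 3. Nothing measured here accounts for this result.

The compounds shown leave open whether a longer chain or a cyclopropyl group at this place would also stay within the scatter of compound 3. They also leave open how much the ester chain and the fluorine pattern each contribute separately, since compounds 1 and 2 differ from compound 3 in more than one place.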